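Cytotoxicity on Vero Cells: Tert-butyl Replacing 4-Fluorophenyl

The source may report more compounds than this note shows. Statements on the series, on what has been measured and on what is new or still open speak of the compounds shown alone.

Measured compounds:
compound 1 `CN1CCN(c2nc3c(cc2[N+](=O)[O-])c(=O)c(C(=O)O)cn3-c2ccc(F)cc2)CC1c1ccccc1`: 124000 nM
compound 2 `CC1CN(c2nc3c(cc2[N+](=O)[O-])c(=O)c(C(=O)O)cn3-c2ccc(F)cc2)CC(C)O1`: 141000 nM
compound 3 `CN1CCN(c2nc3c(cc2[N+](=O)[O-])c(=O)c(C(=O)O)cn3C(C)(C)C)CC1c1ccccc1`: a limit only, > 134000 nM

In an ADME assay on Vero cells (Chlorocebus sabaeus) for cytotoxicity, read by MTT assay, with a stated time of 72 h (a higher number here means a weaker inhibitor, a lower number a stronger inhibitor), compound 1 gives 124000 nM and compound 2 gives 141000 nM. Compound 3 reports only a limit, > 134000 nM. The change tert-butyl in place of 4-fluorophenyl on an aromatic nitrogen produces an at least 1.0-fold higher number from compound 1 to compound 3 (0.03 log units; that floor lies within the scatter), a step whose floor is set by the limit of > 134000 nM in this assay, at which 1 of the 3 values shown sits. The difference between the cores of compound 1 and compound 2 is not broken down here. Compound 4 `CC1CN(c2nc3c(cc2[N+](=O)[O-])c(=O)c(C(=O)O)cn3C(C)(C)C)CC(C)O1` carries the same change on the core of compound 2, namely (tert-butyl in place of 4-fluorophenyl on an aromatic nitrogen). The step from compound 2 to compound 4 is expected to be a 1.1-fold higher number from compound 2 to compound 4 (0.03 log units; within the scatter), resting on the measured step of an at least 1.0-fold higher number from compound 1 to compound 3 (0.03 log units; that floor lies within the scatter) and on the value of compound 2, 141000 nM. Compound 4 is therefore estimated at 150000 nM, between 100000 nM and 250000 nM.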

Compound 4, half-maximal inhibitory concentration: 159000 nM
Estimate against measurement, compound 4: 1.1-fold (0.03 log units) below; the measured number falls inside the stated range.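

In this assay, tert-butyl in place of 4-fluorophenyl on an aromatic nitrogen gives a 1.1-fold higher number from compound 2 to compound 4 (0.05 log units; within the scatter), so on the core of compound 2 the change stays within the scatter. The change has now been read on two cores, and neither step goes beyond the scatter, but this does not establish that it carries over unchanged: the same change on two cores in this assay, an at least 1.0-fold higher number (0.03 log units; that floor lies within the scatter) from compound 1 to compound 3 and a 1.1-fold higher number (0.05 log units; within the scatter) from compound 2 to compound 4; the limit leaves it open whether they differ. Compound 3 gives a limit and not a number: the limit of > 134000 nM in this assay, at which 1 of the 4 values shown sits.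

The compounds shown leave open how other groups on that aromatic nitrogen, such as cyclopropyl or ethyl, would compare with tert-butyl and 4-fluorophenyl. They also leave open whether the change would read alike on a core carrying an amine in place of the nitro group.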